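Pyrimidinyl for pyridinyl on the thioether carbon

This account rests on a few compounds, and the source may have more. Where it says the series, first, only, none or still open, it means among the compounds named here.

Compound 1 `CC(Sc1nc2c(cnn2C)c(=O)n1-c1ccccc1)c1ccccn1` gives 63 nM in an assay on isolated protein for inhibition of retinal dehydrogenase 2 (Homo sapiens); a lower number here means a stronger inhibitor, a higher number a weaker inhibitor. Compound 2 `C#Cc1ccc(-n2c(SC(C)c3ccccc3)nc3c(cnn3C)c2=O)cc1` gives 800 nM. Compound 3 `Cn1ncc2c(=O)n(-c3ccccc3)c(OCc3cccc(F)c3)nc21` gives 3700 nM.

Among these three, compound 1 has the lowest number in this assay: compound 2 sits a good way above it, beyond the scatter, and compound 3 further still. For the measured compounds named here, compound 2 and compound 3 differ from compound 1 in more than one place, so no single step among the measured compounds can be read from them.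

The unmeasured compound 4 `CC(Sc1nc2c(cnn2C)c(=O)n1-c1ccccc1)c1cncnc1` is built from compound 1 by one change: pyrimidin-5-yl in place of pyridin-2-yl on a saturated chain carbon bound to a saturated chain carbon and a sulfur. Going by the values given here, no measured pair isolates this exchange. Compound 2 and compound 3, which carry other groups on that chain carbon or a different linker altogether, give higher numbers than compound 1, but each also changes a second part of the molecule. Given that, compound 4 is expected to sit near compound 1 or somewhat above it, with a step from compound 1 to compound 4 of a 2.4-fold higher number from compound 1 to compound 4 (0.38 log units; beyond the scatter) expected, possibly within the scatter. Compound 4 is estimated at 150 nM in this assay, within a range of 40 nM to 600 nM.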

Compound 4, half-maximal inhibitory concentration: 380 nM
For compound 4 the middle estimate is 2.5-fold (0.40 log units) below the measured one; measured number inside the range.
By their numbers in this assay, from the lowest: compound 1; then compound 4; then compound 2; then compound 3.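

In this assay, for the compounds shown here, the exchange of pyridin-2-yl for pyrimidin-5-yl gives a 6.0-fold higher number from compound 1 to compound 4 (0.78 log units; beyond the scatter) and is the first step at this position that can be read on its own. The number therefore responds to the ring on the saturated chain carbon bound to a saturated chain carbon and a sulfur, even though both rings are six-membered, aromatic and equal in heavy atoms, and differ in their hetero atoms and in where the ring is attached. Nothing available accounts for the size of this step.

The two rings differ both in the count of ring nitrogens and in their attachment, so the compounds shown do not separate these two changes. On these data alone, whether pyridin-3-yl or pyrimidin-2-yl on that carbon would stay nearer compound 1 or compound 4 remains open.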